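The compounds below may be only part of what the source reports. "The series", "measured", "known", "first", "only" and "open" are said of these compounds alone.

Among the compounds with values here, compound 3 `CN(C)CCn1cnnc1-c1cc(Oc2ccc(NC(=O)N/N=C/c3ccc(O)c(O)c3)cc2F)ccn1` is the weakest of the three compounds measured so far: in a functional assay on HT-29 cells (Homo sapiens) for cytotoxicity, read by MTT assay, with a stated time of 72 h (on this read-out higher numbers stand for weaker inhibition and lower numbers for stronger inhibition), compound 3 gives 1890 nM, the highest number of the set. The two compounds nearest to it differ only in the ring attached to the carbon with a double bond to nitrogen. Compound 1 `CN(C)CCn1cnnc1-c1cc(Oc2ccc(NC(=O)N/N=C/c3ccc(F)cc3Cl)cc2F)ccn1` gives 510 nM, and compound 2 `CN(C)CCn1cnnc1-c1cc(Oc2ccc(NC(=O)N/N=C/c3ccc(Cl)cc3)cc2F)ccn1` gives 530 nM; between these two the change is a 1.0-fold higher number from compound 1 to compound 2 (0.02 log units; within the scatter). Moving to the 3,4-dihydroxyphenyl ring of compound 3 gave a 3.7-fold higher number from compound 1 to compound 3 (0.57 log units; beyond the scatter) and a 3.6-fold higher number from compound 2 to compound 3 (0.55 log units; beyond the scatter).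

Compound 4 `CN(C)CCn1cnnc1-c1cc(Oc2ccc(NC(=O)N/N=C/c3cc(Br)c(O)c(Br)c3)cc2F)ccn1` is the unmeasured compound. It differs from compound 3 as follows: 3,5-dibromo-4-hydroxyphenyl in place of 3,4-dihydroxyphenyl on a carbon with a double bond to nitrogen. Within the data shown here, the steps that bear on this change are those from compounds 1 and 2 to compound 3, both modest and beyond the scatter, and both going toward a higher number when two hydroxyls replaced a halogenated ring. Compound 4 keeps one hydroxyl and brings in two bromines, so part of that move is undone. The expected outcome in this assay is therefore a number somewhat lower than that of compound 3, with the step estimated as a 2.5-fold lower number from compound 3 to compound 4 (0.40 log units; beyond the scatter). Compound 4 is estimated at 750 nM, with a likely range from 300 nM to 1900 nM.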

Compound 4, half-maximal inhibitory concentration: 2670 nM
Beside the measured number, compound 4's estimate is 3.6-fold (0.55 log units) below it, outside the stated range (above it).
By their numbers in this assay, from the lowest: compounds 1 and 2 (each within the scatter of the next); then compounds 3 and 4 (each within the scatter of the next).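

In this assay, putting 3,5-dibromo-4-hydroxyphenyl in place of 3,4-dihydroxyphenyl on the carbon with a double bond to nitrogen gives a 1.4-fold higher number from compound 3 to compound 4 (0.15 log units; within the scatter) and so leaves compounds 3 and 4 indistinguishable, even though the two rings differ in their bromines and in their number of hydroxyls. Carrying bromine does not bring compound 4 into line with the halogenated rings that lack a hydroxyl, as the data show a 5.0-fold higher number from compound 2 to compound 4 (0.70 log units; beyond the scatter) and a 5.2-fold higher number from compound 1 to compound 4 (0.72 log units; beyond the scatter) in the same assay, so among these four compounds, with none going against it, the two rings with a hydroxyl give the higher numbers and the two without one give the lower numbers. Nothing measured alongside these compounds offers an explanation for this split.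

The compounds shown leave open whether the hydroxyl itself separates the two pairs, or whether this only appears so in a set of four. A plain phenyl ring, or a ring carrying a methoxy group or an amine in place of the hydroxyl, would help to answer that.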